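This account rests on a few compounds, and the source may have more. Where it says the series, first, only, none or still open, it means among the compounds named here.

Working notes on the sulfonate series in a functional assay on HT-29 cells (Homo sapiens) for antiproliferative activity, read by sulforhodamine B assay, with a stated time of 48 h; on this read-out lower numbers stand for stronger inhibition and higher numbers for weaker inhibition.

Compound 1 `CC(=O)Nc1ccc(S(=O)(=O)Oc2ccccc2C(C)C)cc1` gives 23000 nM in this assay. Compound 2 `CCCCCC(=O)Nc1ccc(S(=O)(=O)Oc2ccccc2C(C)C)cc1` gives 6400 nM, and the step of a 3.6-fold lower number from compound 1 to compound 2 (0.56 log units; beyond the scatter) shows that lengthening the acyl chain lowers the number. Compound 3 `CCCCCC(=O)Nc1ccc(S(=O)(=O)Oc2ccccc2I)cc1` gives 13000 nM; the step of a 2.0-fold higher number from compound 2 to compound 3 (0.31 log units; beyond the scatter) goes the other way, so that compound 3 stands second highest of the three numbers, within the scatter of compound 1 and beyond it only against compound 2.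

The next member, compound 4 `O=C(CCCCl)Nc1ccc(S(=O)(=O)Oc2ccccc2I)cc1`, differs from compound 3 in one place: chloro in place of ethyl on a saturated chain carbon, three bonds along the chain from a carbonyl carbon. Among the compounds with values here, the only measured step that bears on the acyl chain is a 3.6-fold lower number from compound 1 to compound 2 (0.56 log units; beyond the scatter), which spoke for a longer chain; here the chain is cut by two carbons and ends in chloro instead, a change for which no measured pair exists. Within the data shown here, on that single precedent the expected direction is a somewhat higher number, but no measured step supports a shift beyond the scatter. The step from compound 3 to compound 4 is therefore estimated as a 1.2-fold higher number from compound 3 to compound 4 (0.09 log units; within the scatter) in this assay. Compound 4 is expected to give about 16000 nM, within a range of 7000 nM to 36000 nM.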

Compound 4, half-maximal inhibitory concentration: 9100 nM
Compound 4: the middle estimate sits 1.8-fold (0.25 log units) above what was measured; the range from low to high includes it.
By their numbers in this assay, from the lowest: compounds 2, 4, 3 and 1 (each within the scatter of the next, the first and the last beyond it).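

In this assay, the first thing this pair adds is a change on the acyl chain of the iodo compounds, where the earlier chain step a 3.6-fold lower number from compound 1 to compound 2 (0.56 log units; beyond the scatter) came from the isopropyl compounds. Here, chloro in place of ethyl on a saturated chain carbon, three bonds along the chain from a carbonyl carbon, gives a 1.4-fold lower number from compound 3 to compound 4 (0.15 log units; within the scatter), so pentyl and 3-chloropropyl cannot be told apart at this position in this assay. No measured evidence on the compounds shown explains this outcome.

From the compounds shown here alone, the pair changes chain length and brings in chloro in a single step, so the part of each stays open, and a chain of the same length without chloro would be needed to separate them; the same holds for whether a 3-chloropropyl chain behaves alike with isopropyl in place of iodo. Also open, going by these compounds, is how an amine, a hydroxyl or a carboxylic acid in place of chloro at this carbon, or a longer chain ending in chloro, would read in this assay.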